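This account rests on a few compounds, and the source may have more. Where it says the series, first, only, none or still open, it means among the compounds named here.

Compound 1, `CN(C)CCCNc1nc(-c2ccc(NC(=O)Nc3ccc(F)cc3)cc2)nc2c(Cl)c(Cl)sc12`, gives 430 nM; compound 2, `CN(C)CCNc1nc(-c2ccc(NC(=O)Nc3ccccc3)cc2)nc2ccsc12`, gives 620 nM; compound 3, `CCN(CC)CCCNc1nc(-c2ccc(NC(=O)Nc3ccccc3)cc2)nc2ccsc12`, gives 730 nM.

In a functional assay on HT-29 cells (Homo sapiens) for cytotoxicity, read by MTT assay, with a stated time of 72 h (a lower number here means a stronger inhibitor, a higher number a weaker inhibitor), compound 3 shows the highest of the three numbers, yet its gaps to compound 2 and to compound 1 both lie within the scatter, so the three compounds cannot be told apart on these data. Compound 4 `CCN(CC)CCCNc1nc(-c2ccc(NC(=O)Nc3ccc(C)cc3)cc2)nc2ccsc12` differs from compound 3 by methyl in place of hydrogen on an aromatic carbon. Among the compounds with values here, no measured step touches this position: the only single-place step, a 1.2-fold higher number from compound 2 to compound 3 (0.07 log units; within the scatter), concerns the amine end of the chain, not the ring of the urea. Within the data shown here, compound 1 differs from compound 3 in more than one place at once, so its number sets no step for this change. With nothing bearing on the change, the expectation for compound 4 is no step beyond the scatter, a 1.0-fold lower number from compound 3 to compound 4 (0.02 log units; within the scatter). Compound 4 is therefore estimated at 700 nM, with a range from 300 nM to 1700 nM.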

Compound 4, half-maximal inhibitory concentration: 1620 nM
Beside the measured number, compound 4's estimate is 2.3-fold (0.36 log units) below it, and the stated range covers the measured number.
By their numbers in this assay, from the lowest: compounds 1, 2 and 3 (each within the scatter of the next); then compound 4.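

In this assay the ring at the far end of the urea proves sensitive to a very small change. Methyl in place of hydrogen on this ring, para to a large group, gives a 2.2-fold higher number from compound 3 to compound 4 (0.35 log units; beyond the scatter) and so is the only single-place step here that lies beyond the scatter, while the earlier change at the amine end, a 1.2-fold higher number from compound 2 to compound 3 (0.07 log units; within the scatter), stays within it. No measurement at hand accounts for this step.

Going by these compounds, what a methoxy group, a chlorine atom or an ethyl group would do at this same place on compound 3 stays open. Also open, on these data alone, is whether methyl here would give a step of similar size with the dimethylamino chain of compound 2 in place of the chain of compound 3.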